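A few compounds are considered here, and "the series" means these few. Any claim that something is new, unique, unknown or untested is made for them only; others in the source may bear on it.

Within the data shown here, compound 1 `CN(CC1CCN(CCCc2c[nH]c3ccc(-n4cnnc4)cc23)CC1)C(=O)Nc1ccccc1` stands at the lowest number of the three compounds measured so far. In an assay on CHO cells for displacement of a labelled ligand from 5-hydroxytryptamine receptor 1B (Homo sapiens) (on this read-out higher numbers stand for weaker inhibition and lower numbers for stronger inhibition), compound 1 gives 6.2 nM; compound 2 `C[C@H](NCC1CCN(CCCc2c[nH]c3ccc(-n4cnnc4)cc23)CC1)c1ccccc1` gives 58 nM, and compound 3 `CN(Cc1ccco1)C1CCN(CCCc2c[nH]c3ccc(-n4cnnc4)cc23)CC1` gives 89 nM. Compound 4 `c1ccc(NCC2CCN(CCCc3c[nH]c4ccc(-n5cnnc5)cc34)CC2)nc1` has not yet been measured. It differs from compound 1 in a single place: (pyridin-2-yl)amino in place of methyl(phenylcarbamoyl)amino on a saturated chain carbon bound to a saturated ring carbon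

Among the measured compounds shown here, only one of the measured steps bears directly on this exchange. In the step of a 9.4-fold higher number from compound 1 to compound 2 (0.97 log units; beyond the scatter) the same methyl(phenylcarbamoyl)amino group of compound 1 was removed and an amine bearing one aromatic ring was put in its place, and the number rose well beyond the scatter. The other step, a 1.5-fold higher number from compound 2 to compound 3 (0.19 log units; within the scatter), changes a different part of the molecule and stays within the scatter, so it says little about the group that changes here. For the measured compounds named here, because the step of a 9.4-fold higher number from compound 1 to compound 2 (0.97 log units; beyond the scatter) shows that giving up this group costs potency, a higher number is expected for compound 4 than for compound 1, though the size remains uncertain, as only one comparable step exists. Compound 4 is therefore estimated to give 35 nM in this assay, with a range from 12 nM to 120 nM. That estimate means an expected step of a 5.6-fold higher number from compound 1 to compound 4 (0.75 log units; beyond the scatter).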

Compound 4, half-maximal inhibitory concentration: 3.3 nM
For compound 4 the middle estimate is 11-fold (1.03 log units) above the measured one; measured number below the stated range.
By their numbers in this assay, from the lowest: compounds 4 and 1 (each within the scatter of the next); then compounds 2 and 3 (each within the scatter of the next).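

In this assay, the methyl(phenylcarbamoyl)amino group on a saturated chain carbon bound to a saturated ring carbon proves replaceable, since exchanging it for (pyridin-2-yl)amino gives a 1.9-fold lower number from compound 1 to compound 4 (0.27 log units; within the scatter) and the two compounds cannot be told apart. The earlier rise on leaving that group therefore does not hold for every amine in its place: the group on the amine nitrogen makes a large difference, with pyridin-2-yl in place of 1-phenylethyl giving an 18-fold lower number from compound 2 to compound 4 (1.24 log units; beyond the scatter) and leaving compound 4 level with compound 1 rather than with compound 2. The change on the saturated ring carbon is also large, as ((pyridin-2-yl)amino)methyl in place of ((furan-2-yl)methyl)(methyl)amino gives a 27-fold lower number from compound 3 to compound 4 (1.43 log units; beyond the scatter) in the same assay.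

Nothing available accounts for the gap between the pyridin-2-yl and 1-phenylethyl groups. As far as these compounds go, it remains open whether a pyridin-3-yl or benzyl group on that amine nitrogen, or a methyl group added to it alongside pyridin-2-yl, would keep the number as low as in compound 4.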